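This account rests on a few compounds, and the source may have more. Where it says the series, first, only, none or still open, it means among the compounds named here.

Of the compounds shown here, three that share one core have been measured in a functional assay on U-373MG ATCC cells (Homo sapiens) for inhibition, read by MTT assay, with a stated time of 72 h; on this read-out higher numbers stand for weaker inhibition and lower numbers for stronger inhibition. Compound 1 `CC1(C)CC(NC(=O)Nc2ccccc2Cl)c2cc(Cl)ccc2O1` gives 17000 nM, compound 2 `CC(C)NC(=O)NC1CC(C)(C)Oc2ccc(Cl)cc21` gives 62000 nM, and compound 3 `CC1(C)CC(NC(=O)Nc2ccc(Cl)cc2)c2cc(Cl)ccc2O1` gives 19000 nM. Compound 3 therefore stands level with one neighbour and clearly apart from the other: its nearest comparison is a 1.1-fold higher number from compound 1 to compound 3 (0.05 log units; within the scatter), and its furthest is a 3.3-fold lower number from compound 2 to compound 3 (0.51 log units; beyond the scatter).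

Compound 4 `CC1(C)CC(NC(=O)Nc2cccc(Cl)c2)c2cc(Cl)ccc2O1` has not yet been measured. It carries 3-chlorophenyl in place of 4-chlorophenyl on an amide-type nitrogen.

The measured step closest in kind is the exchange of 2-chlorophenyl for 4-chlorophenyl at that same place, a 1.1-fold higher number from compound 1 to compound 3 (0.05 log units; within the scatter), which stays within the scatter. The two larger steps, a 3.6-fold higher number from compound 1 to compound 2 (0.56 log units; beyond the scatter) and a 3.3-fold lower number from compound 2 to compound 3 (0.51 log units; beyond the scatter), are modest, but both swap an aromatic group with isopropyl, and the present change does nothing of that kind. Going by the values given here, no measured compound yet carries 3-chlorophenyl, so the data offer no direct reading of this group. On this evidence, no change beyond the scatter is expected in this assay, and no direction is favoured. The expected step is a 1.1-fold lower number from compound 3 to compound 4 (0.02 log units; within the scatter). For compound 4 the estimated value is 18000 nM, with an expected range of 9000 nM to 36000 nM.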

Compound 4, half-maximal inhibitory concentration: 21000 nM
Compound 4: the middle estimate sits 1.2-fold (0.07 log units) below what was measured; the measured number falls inside the stated range.
By their numbers in this assay, from the lowest: compounds 1, 3 and 4 (each within the scatter of the next); then compound 2.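

In this assay, the 3-chlorophenyl group now joins the 2-chlorophenyl and 4-chlorophenyl groups on the amide-type nitrogen, and the reading at this place does not separate it from either of them. Both a 1.1-fold higher number from compound 3 to compound 4 (0.04 log units; within the scatter) and a 1.2-fold higher number from compound 1 to compound 4 (0.09 log units; within the scatter) stay within the scatter, so compounds 1, 3 and 4 stand level and cannot be put in any order. The contrast with the isopropyl group now holds for all three chlorophenyl groups rather than two, since a 3.0-fold lower number from compound 2 to compound 4 (0.47 log units; beyond the scatter) also lies beyond the scatter, though it is modest.

On these data alone, what stays open is whether this level reading extends past chlorine, for instance to a phenyl group with no substituent, a methoxyphenyl or a pyridyl group on the same nitrogen, or to a carboxylic acid or an amine carried on the phenyl ring. Nothing at hand explains why the three chlorophenyl compounds read alike or why compound 2 stands apart from them.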